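Trimming a methyl from a weak furan-bearing aniline

This account rests on a few compounds, and the source may have more. Where it says the series, first, only, none or still open, it means among the compounds named here.

In a functional assay for inhibition, with Homo sapiens as the target (on this read-out lower numbers stand for stronger inhibition and higher numbers for weaker inhibition), compound 1 `CCN(CC)c1ccc(Nc2nccc(-c3ccc(C)o3)n2)cc1` gives 28000 nM, the highest of the two numbers recorded; compound 2 `c1cc(Nc2nccc(-c3ccco3)n2)cc(OCCn2ccnc2)c1` gives 200 nM in this assay, a gap well beyond the usual scatter, though these two compounds differ in more than one place, so their values are simply reported side by side. Compound 3 `CCN(CC)c1ccc(Nc2nccc(-c3ccco3)n2)cc1` differs from compound 1 in a single way: hydrogen in place of methyl on an aromatic carbon, that is, 5-methylfuran-2-yl becomes furan-2-yl. Within the data shown here, with no measured step of this kind to lean on, a modest move toward stronger inhibition is expected, a 2.8-fold lower number from compound 1 to compound 3 (0.45 log units; beyond the scatter). Compound 3 is therefore estimated at 10000 nM, within a range of 2500 nM to 40000 nM.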

Compound 3, half-maximal inhibitory concentration: 8700 nM
Compound 3: middle estimate off by 1.1-fold (0.06 log units), on the high side, and the stated range covers the measured number.
By their numbers in this assay, from the lowest: compound 2; then compound 3; then compound 1.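

Among these compounds, compound 1 and compound 3 are the first pair here that isolates one change, and in this assay the step is a 3.2-fold lower number from compound 1 to compound 3 (0.51 log units; beyond the scatter). The position on the furan next to the ring oxygen therefore affects the read-out, and the methyl there is not needed for inhibition. Nothing measured here gives a reason for this step.

Still open, as far as these compounds go, is how other groups at this position, such as ethyl, chlorine or an amine, would compare with hydrogen and methyl. Also open, from the compounds shown here alone, is whether removing the methyl gives a similar step when the rest of the molecule is different.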